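Methoxy to Trifluoromethyl on a Cytotoxic Benzylidene Core

A few compounds are considered here, and "the series" means these few. Any claim that something is new, unique, unknown or untested is made for them only; others in the source may bear on it.

Measured compounds:
compound 1 `C=CCn1c(=O)/c(=C\c2cccc(F)c2)[nH]c(=O)/c1=C\c1ccccc1OC` gives 9100 nM
compound 2 `C=CCn1c(=O)/c(=C\c2cccc(Br)c2)[nH]c(=O)/c1=C\c1ccccc1OC` gives 5400 nM
compound 3 `C=CCn1c(=O)/c(=C\c2ccccc2OC)[nH]c(=O)/c1=C\c1ccccc1OC` gives 6900 nM

Three compounds on a shared core were tested in a functional assay on HeLa cells (Homo sapiens) for cytotoxicity, read by CCK-8 assay, with a stated time of 72 h; a lower number here means a stronger inhibitor, a higher number a weaker inhibitor. Compound 3 stands second highest of the three numbers. Its nearest neighbour is compound 2, with a 1.3-fold higher number from compound 2 to compound 3 (0.11 log units; within the scatter); its furthest is compound 1, with a 1.3-fold lower number from compound 1 to compound 3 (0.12 log units; within the scatter). Both steps lie within the scatter, as does a 1.7-fold lower number from compound 1 to compound 2 (0.23 log units; within the scatter), so the three values show no separation that can be trusted.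

Compound 4 `C=CCn1c(=O)/c(=C\c2ccccc2C(F)(F)F)[nH]c(=O)/c1=C\c1ccccc1OC` differs from compound 3 in one place: trifluoromethyl in place of methoxy on an aromatic carbon. Going by the values given here, none of the measured steps touches this change. The steps that exist vary the other ring in the core, or swap one halogen for another, and every one of them stays within the scatter. There is therefore no measured ground for expecting the exchange of methoxy for trifluoromethyl to move the number beyond the scatter, and the step is expected to be small, a 1.1-fold lower number from compound 3 to compound 4 (0.03 log units; within the scatter).

Compound 4 is estimated at 6500 nM in this assay, with a range from 2500 nM to 17000 nM.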

Compound 4, half-maximal inhibitory concentration: 4600 nM
Beside the measured number, compound 4's estimate is 1.4-fold (0.15 log units) above it; measured number inside the range.
By their numbers in this assay, from the lowest: compounds 4, 2, 3 and 1 (each within the scatter of the next).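

In this assay the exchange of trifluoromethyl for methoxy on an aromatic carbon, ortho to a large group, gives a step that can be read directly at this position (a 1.5-fold lower number from compound 3 to compound 4 (0.18 log units; within the scatter)), and it stays within the scatter even though 4 heavy atoms and no hydrogen-bond acceptor replace 2 heavy atoms and 1 hydrogen-bond acceptor. The 2-(trifluoromethyl)phenyl group also shows no separation from the 3-bromophenyl group (a 1.2-fold lower number from compound 2 to compound 4 (0.07 log units; within the scatter)) or from the 3-fluorophenyl group (a 2.0-fold lower number from compound 1 to compound 4 (0.30 log units; within the scatter)), so all four compounds remain unseparated and this position has yet to show a step beyond the scatter. No measurement is available that could explain why this change leaves the number within the scatter.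

The compounds shown leave open whether an amine, a carboxylic acid or a longer chain in place of trifluoromethyl on this aromatic carbon would produce a step beyond the scatter. They also leave open what a change would do on the other side of the shared core, where the second 2-methoxyphenyl group is the same in all four compounds.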